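Ring substituents on the chain: from compound 2 to compound 3

A few compounds are considered here, and "the series" means these few. Any claim that something is new, unique, unknown or untested is made for them only; others in the source may bear on it.

Within the data shown here, in a functional assay for inhibition, with Homo sapiens as the target (a lower number here means tighter binding, a higher number weaker binding), compound 2 (`CC(C)(Cc1ccccc1)C1OCC(C/C=C\CCC(=O)O)C(c2cccnc2)O1`) gives 513 nM, the higher of the two numbers so far, and compound 1 (`CSc1ccccc1OC(C)(C)C1OCC(C/C=C\CCC(=O)O)C(c2cccnc2)O1`) gives 89.1 nM. Compound 3 (`CC(C)(Cc1ccc(F)cc1C#N)C1OCC(C/C=C\CCC(=O)O)C(c2cccnc2)O1`) has not yet been measured. It differs from compound 2 as follows: 2-cyano-4-fluorophenyl in place of phenyl on a saturated chain carbon, two bonds along the chain from a saturated ring carbon. Among the measured compounds shown here, only one measured step bears on this change, and only indirectly: a 5.8-fold higher number from compound 1 to compound 2 (0.76 log units; beyond the scatter), with benzyl in place of 2-(methylsulfanyl)phenoxy. Compound 1, with the substituted ring, holds the lower number, but this single pair also differs in more than the ring substituent. A modest move to a lower number is therefore expected in this assay, and the expected step is a 2.9-fold lower number from compound 2 to compound 3 (0.45 log units; beyond the scatter). For compound 3 the estimated value is 180 nM, within an expected range of 60 nM to 500 nM.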

Compound 3, dissociation constant: 2.19 nM
Compound 3: middle estimate off by 82-fold (1.91 log units), on the high side; the measured number lies below the stated range.
By their numbers in this assay, from the lowest: compound 3; then compound 1; then compound 2.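

In this assay, the ring on the saturated chain carbon, two bonds along the chain from a saturated ring carbon, proves far more responsive to substitution than the earlier pair could show: 2-cyano-4-fluorophenyl in place of phenyl gives a 230-fold lower number from compound 2 to compound 3 (2.37 log units; beyond the scatter). The new group also surpasses the 2-(methylsulfanyl)phenoxy arrangement, with a 41-fold lower number from compound 1 to compound 3 (1.61 log units; beyond the scatter), so compound 1 no longer marks the low end of the series. Nothing available accounts for the size of this gain.

The compounds shown do not divide the step between the nitrile and the fluorine, since the two enter together. They also leave open whether another group on this ring, such as chlorine, trifluoromethyl or an amine, would give a similar number.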